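Compound 3 to compound 4: ethoxy gives way to fluoro

This account rests on a few compounds, and the source may have more. Where it says the series, first, only, none or still open, it means among the compounds named here.

In a functional assay on MCF7 cells (Homo sapiens) for antiproliferative activity, read by MTT assay, with a stated time of 72 h (on this read-out lower numbers stand for stronger inhibition and higher numbers for weaker inhibition), compound 1 (`CCOc1ccc(-c2ncnn2-c2cc(OC)c(OC)c(OC)c2)cc1Cl`) gives 17 nM as its value. Compound 3 (`CCOc1ccc(-c2ncnn2-c2cc(OC)c(OC)c(OC)c2)cc1`) gives 50 nM as the higher of the two actual numbers in the series. Compound 2 (`CCOc1cccc(-c2ncnn2-c2cc(OC)c(OC)c(OC)c2)c1`) is recorded at > 10000 nM and this is a limit of the assay, not a number.

Compound 4 (`COc1cc(-n2ncnc2-c2ccc(F)cc2)cc(OC)c1OC`) carries fluoro in place of ethoxy on an aromatic carbon, para to a large group (fluoro in place of ethoxy on an aromatic carbon). Going by the values given here, the one measured step, hydrogen in place of chloro, is a 2.9-fold higher number from compound 1 to compound 3 (0.47 log units; beyond the scatter) and does not touch the ethoxy group. Among the compounds with values here, every measured compound keeps an ethoxy group, so no step tests its loss directly, and that step is only a loose guide.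

Starting from compound 3 at 50 nM a higher number is expected in this assay with a step larger than the modest one seen so far. The expected change is a 10-fold higher number from compound 3 to compound 4 (1.00 log units; beyond the scatter) with much uncertainty. For compound 4 the estimate is 500 nM with an expected range from 60 nM to 5000 nM as its span.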

Compound 4, half-maximal inhibitory concentration: > 10000 nM
Compound 4: only a limit was reported; the forecaster's own chance of this, stated with the estimate: 20%; at least 20-fold (1.30 log units) between middle value and limit.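

In the working series, the position para to a large group now has a direct test in this assay: fluoro in place of ethoxy gives an at least 200-fold higher number from compound 3 to compound 4 (2.30 log units; beyond the scatter), a large step, whereas hydrogen in place of chloro gave only a 2.9-fold higher number from compound 1 to compound 3 (0.47 log units; beyond the scatter). Compound 4 is recorded at > 10000 nM, which is a limit and not a number. Activity in this short series is therefore seen only with ethoxy at this position, as in compound 1 and compound 3, while compound 2, with its ethoxy placed differently, and compound 4 share one ceiling: the limit of > 10000 nM in this assay, at which 2 of the 4 values shown sit.

From the compounds shown here alone, whether the loss of ethoxy or the arrival of fluoro drives the step remains open, as does how a methoxy group, a propoxy chain or an amine would read at this position. Also open, going by these compounds, is whether chloro on the ring of compound 4 would bring any activity back.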